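Removing the methyl from the aryl oxygen of compound 2

The source may report more compounds than this note shows. Statements on the series, on what has been measured and on what is new or still open speak of the compounds shown alone.

Among the measured compounds shown here, compound 2 `COc1cc(C)cc(-c2nn(CC#N)cc2-c2ccnc(-c3ccc(N(C)C)cc3)c2)c1` stands highest of the two numbers known in a functional assay on IGROV-1 cells (Homo sapiens) for cytotoxicity, read by sulforhodamine B assay, with a stated time of 48 h, tested at 0.01 uM (on this read-out lower numbers stand for a stronger effect and higher numbers for a weaker effect at the one concentration tested), where compound 2 gives 101%. Its nearest neighbour, compound 1 `Cc1cc(O)cc(-c2nn(CC#N)cc2-c2ccnc(-c3ccc(Oc4ccccc4)cc3)c2)c1`, gives in this assay 83%, a number that lies beyond the usual scatter from compound 2. Compound 1 and compound 2 differ in two places at once, so their values show only the gap between them and no single change can be tied to it. The compound that has not yet been measured is compound 3 `Cc1cc(O)cc(-c2nn(CC#N)cc2-c2ccnc(-c3ccc(N(C)C)cc3)c2)c1`, which differs from compound 2 as follows: hydrogen in place of methyl on an oxygen on an aromatic ring. For the measured compounds named here, no measured pair shows this change alone. Because compound 2 gives 101% and nothing known isolates the effect of the hydroxy for methoxy exchange, compound 3 is expected to move little, with the step of a number 6 percentage points lower from compound 2 to compound 3 (within the scatter) staying within the scatter or drifting slightly downward. The estimate for compound 3 in this assay is 95%, with a range from 78% to 108%.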

Compound 3, a percentage reported as activity, at one concentration (the size of the read-out at that concentration, not a potency): 94%
For compound 3 the middle estimate is 1 percentage points above the measured one; the range from low to high includes it.
By their numbers in this assay, from the lowest: compound 1; then compounds 3 and 2 (each within the scatter of the next).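

In this assay the exchange of methoxy for hydroxy can now be read alone, and it gives a number 7 percentage points lower from compound 2 to compound 3 (within the scatter) on the oxygen of the 3-methoxy-5-methylphenyl group, so this change shows no effect that stands out from the scatter. Among the compounds shown here, with the hydroxy held in place, dimethylamino in place of phenoxy gives a modest step (a number 11 percentage points higher from compound 1 to compound 3 (beyond the scatter)), so among the single changes read here, only the one on the other aromatic ring goes beyond the scatter. Nothing available explains either step.

Still open, as far as these compounds go, is whether a longer chain such as ethoxy, or a carboxylic acid, would be tolerated on this oxygen. From the compounds shown here alone, it is also open whether a morpholine in place of the dimethylamino would keep the number of compound 3 or move it.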